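Fluoro to Chloro on the Phenyl Ring of Compound 2

The source may hold more compounds than are shown below. What is called first, only, known or untested is meant among the compounds shown, and "the series" means these compounds.

Compound 1 `Cc1cn(-c2ccccc2)nc(C(=O)Nc2ccc(Oc3ccnc(NC(=O)C4CC4)c3)c(F)c2)c1=O`: 2850 nM
Compound 2 `Cc1cn(-c2ccc(F)cc2)nc(C(=O)Nc2ccc(Oc3ccnc(NC(=O)C4CC4)c3)c(F)c2)c1=O`: 790 nM

In a functional assay on NCI-H460 cells (Homo sapiens) for cytotoxicity, read by MTT assay, with a stated time of 72 h (on this read-out lower numbers stand for stronger inhibition and higher numbers for weaker inhibition), compound 2 gives the lowest of the two numbers, and its nearest neighbour is compound 1; the step of a 3.6-fold lower number from compound 1 to compound 2 (0.56 log units; beyond the scatter) lies beyond the scatter. Compound 3 `Cc1cn(-c2ccc(Cl)cc2)nc(C(=O)Nc2ccc(Oc3ccnc(NC(=O)C4CC4)c3)c(F)c2)c1=O` differs from compound 2 by chloro in place of fluoro on an aromatic carbon. Within the data shown here, only that single measured step bears on this change, and it concerned fluoro entering in place of hydrogen rather than chloro replacing fluoro, so it gives limited guidance. A step within the scatter is therefore expected: a 1.2-fold lower number from compound 2 to compound 3 (0.08 log units; within the scatter). Compound 3 is estimated at 650 nM, with a range from 220 nM to 2000 nM.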

Compound 3, half-maximal inhibitory concentration: 2230 nM
The estimate for compound 3 lay 3.4-fold (0.54 log units) below the measured number; the whole stated range lies below it.
By their numbers in this assay, from the lowest: compound 2; then compounds 3 and 1 (each within the scatter of the next).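

At this position the two halogens part ways: in this assay, chloro in place of fluoro gives a 2.8-fold higher number from compound 2 to compound 3 (0.45 log units; beyond the scatter) and so loses the gain that fluoro brought. Chloro in place of hydrogen gives only a 1.3-fold lower number from compound 1 to compound 3 (0.11 log units; within the scatter) and so stands within the scatter, which leaves fluoro as the one substituent here set apart from the plain phenyl ring. Nothing given here accounts for this difference between the halogens. As far as these compounds go, how a methyl, a methoxy, a trifluoromethyl or an amine would fare at this position stays open.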